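Putting a Tetrazole Where a Methylsulfanyl Group Stood

This account rests on a few compounds, and the source may have more. Where it says the series, first, only, none or still open, it means among the compounds named here.

Compound 1 `CCc1cc(C(C)=O)c(O)cc1OCCCCCC(C)(C)c1nnnn1C` gives 99% in an assay on isolated protein for inhibition of leukotriene B4 receptor 1 (Homo sapiens), tested at 10 uM (on this read-out lower numbers stand for less inhibition and higher numbers for more inhibition at the one concentration tested (going by the name of the read-out)), and compound 2 `CCc1cc(C(C)=O)c(O)cc1OCCCCCC(C)(C)c1nnn(C)n1` gives 95%; the step of a number 4 percentage points lower from compound 1 to compound 2 (within the scatter) stays within the scatter. Compound 3 `CCc1cc(C(C)=O)c(O)cc1OCCCCCCSC` gives 71%, the lowest of the three numbers, with the steps of a number 28 percentage points lower from compound 1 to compound 3 (beyond the scatter) and a number 24 percentage points lower from compound 2 to compound 3 (beyond the scatter) both beyond the scatter. Compound 4 `CCc1cc(C(C)=O)c(O)cc1OCCCCCCc1nnn[nH]1` differs from compound 3 by 1H-tetrazol-5-yl in place of methylsulfanyl on a saturated chain carbon, six bonds along the chain from an oxygen on an aromatic ring. The two steps in which a tetrazole-containing group stood in the place of the methylsulfanyl group of compound 3 both ran toward higher inhibition, so a rise beyond the scatter is expected here as well. Compound 4 is therefore estimated at 90%, with a range from 70% to 100%, meaning an expected step of a number 19 percentage points higher from compound 3 to compound 4 (beyond the scatter).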

Compound 4, a percentage reported as inhibition, at one concentration (the size of the read-out at that concentration, not a potency): 91%
For compound 4 the middle estimate is 1 percentage points below the measured one; low and high end bracket the measured number.
By their numbers in this assay, from the lowest: compound 3; then compounds 4, 2 and 1 (each within the scatter of the next).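

In this assay, 1H-tetrazol-5-yl in place of methylsulfanyl gives a number 20 percentage points higher from compound 3 to compound 4 (beyond the scatter), so a tetrazole at this chain end raises the number without any methyl group on the ring or on the chain carbon that bears it. Those extra methyl groups add nothing that can be told apart here, with a number 4 percentage points lower from compound 2 to compound 4 (within the scatter) and a number 8 percentage points lower from compound 1 to compound 4 (within the scatter). Nothing among the available data explains the rise. As far as these compounds go, whether a carboxylic acid or an amine at this chain end would match the tetrazole remains open, as does the effect of a longer chain carrying it.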